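Methoxy on the Benzyl Ring: Compound 3 to Compound 4

The compounds below may be only part of what the source reports. "The series", "measured", "known", "first", "only" and "open" are said of these compounds alone.

Measured so far in an assay for inhibition of Polyunsaturated fatty acid 5-lipoxygenase (Homo sapiens), read by HPLC, with stated times of 15 min and 10 min; a lower number here means a stronger inhibitor, a higher number a weaker inhibitor:
Compound 1, `Cc1ccc(C(=O)NCc2ccccc2C(F)(F)F)cc1C#CC(C)N(O)C(N)=O`, gives 1700 nM.
Compound 2, `C[C@H](C#Cc1cccc(C(=O)NCc2ccccc2C(F)(F)F)c1)N(O)C(N)=O`, gives 600 nM.
Compound 3, `CC(C#Cc1cccc(C(=O)NCc2ccccc2C(F)(F)F)c1)N(O)C(N)=O`, gives 700 nM.

Compound 3 stands second highest of the three numbers. Its nearest neighbour is compound 2, and the step of a 1.2-fold higher number from compound 2 to compound 3 (0.07 log units; within the scatter) lies within the scatter; the two compounds differ only in that (the fact that one of compounds 2 and 3 is drawn with a defined configuration and the other without, at the place where they differ). The furthest is compound 1, and the step of a 2.4-fold lower number from compound 1 to compound 3 (0.39 log units; beyond the scatter), a hydrogen in place of methyl on an aromatic carbon of the shared core, is modest but beyond the scatter.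

Compound 4, `COc1ccc(CNC(=O)c2cccc(C#CC(C)N(O)C(N)=O)c2)c(C(F)(F)F)c1`, is not yet measured. It differs from compound 3 by methoxy in place of hydrogen on an aromatic carbon. Neither measured step touches this part of the molecule: one changes a methyl on the central ring, the other only the drawn configuration at a chain carbon. So there is no directly relevant precedent here, and the two steps that exist are small or within the scatter. On that basis a step of no change at the digits printed from compound 3 to compound 4 (within the scatter) in this assay is expected, that is, none beyond the scatter. Compound 4 is therefore estimated to give 700 nM, within a range from 300 nM to 1600 nM.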

Compound 4, half-maximal inhibitory concentration: 1700 nM
Estimate against measurement, compound 4: 2.4-fold (0.39 log units) below; the whole stated range lies below it.
By their numbers in this assay, from the lowest: compounds 2 and 3 (each within the scatter of the next); then compounds 1 and 4 (each within the scatter of the next).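

Among the compounds shown here, the earlier steps touched other parts of the molecule, so this is the first reading on the six-membered aromatic ring that carries the trifluoromethyl group: in this assay, methoxy in place of hydrogen on an aromatic carbon, meta to a trifluoromethyl group and para to a large group, goes with a 2.4-fold higher number from compound 3 to compound 4 (0.39 log units; beyond the scatter) and so a weaker inhibitor. This ring therefore does not leave the number untouched when a group is added, and a higher number with an added group on an aromatic carbon now appears at two separate places, since the methyl case reads as a 2.4-fold lower number from compound 1 to compound 3 (0.39 log units; beyond the scatter) when that methyl is taken away. Nothing at hand explains why the methoxy step goes this way.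

A single group at a single place leaves open whether a smaller fluorine, a hydroxyl, an amine or a longer chain such as ethoxy would raise the number as well, or by how much. It also leaves open whether methoxy on another carbon of this ring would give a similar step, and whether the oxygen or the attached methyl matters more.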